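The source may report more compounds than this note shows. Statements on the series, on what has been measured and on what is new or still open speak of the compounds shown alone.

In a functional assay on MKN-45 cells (Homo sapiens) for cytotoxicity, read by MTT assay, with a stated time of 72 h (a lower number here means a stronger inhibitor, a higher number a weaker inhibitor), three compounds have been measured:

compound 1 `COc1ccc(OC)c(/C=N/NC(=O)Nc2ccc(Oc3ccnc(-c4nncn4CCN(C)C)c3)c(F)c2)c1`: 1510 nM
compound 2 `CN(C)CCn1cnnc1-c1cc(Oc2ccc(NC(=O)N/N=C/c3cccc(O)c3)cc2F)ccn1`: 1370 nM
compound 3 `CN(C)CCn1cnnc1-c1cc(Oc2ccc(NC(=O)N/N=C/c3c(Cl)cccc3Cl)cc2F)ccn1`: 160 nM

Compound 3 stands at the lowest number of the three; the others sit well above it, with a 9.4-fold lower number from compound 1 to compound 3 (0.97 log units; beyond the scatter) and an 8.6-fold lower number from compound 2 to compound 3 (0.93 log units; beyond the scatter) both beyond the scatter, while compound 1 and compound 2 differ only within the scatter (a 1.1-fold lower number from compound 1 to compound 2 (0.04 log units; within the scatter)). Compound 4 `COc1cc(/C=N/NC(=O)Nc2ccc(Oc3ccnc(-c4nncn4CCN(C)C)c3)c(F)c2)cc(OC)c1OC` is compound 3 with 3,4,5-trimethoxyphenyl in place of 2,6-dichlorophenyl on a carbon with a double bond to nitrogen. The two steps that bear on this change both ran from a methoxy- or hydroxy-bearing phenyl to the 2,6-dichlorophenyl and lowered the number clearly, as a 9.4-fold lower number from compound 1 to compound 3 (0.97 log units; beyond the scatter) and an 8.6-fold lower number from compound 2 to compound 3 (0.93 log units; beyond the scatter) show. Reversing that direction, compound 4 is expected to give a clearly higher number than compound 3 in this assay, close to the level of compound 1, a step of about a 7.5-fold higher number from compound 3 to compound 4 (0.88 log units; beyond the scatter). Compound 4 is therefore estimated at 1200 nM, with a likely range of 400 nM to 3600 nM.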

Compound 4, half-maximal inhibitory concentration: 2900 nM
The estimate for compound 4 lay 2.4-fold (0.38 log units) below the measured number, within the range that was stated.
By their numbers in this assay, from the lowest: compound 3; then compounds 2, 1 and 4 (each within the scatter of the next, the first and the last beyond it).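

In this assay, for the compounds shown here, 3,4,5-trimethoxyphenyl on this carbon gives up what 2,6-dichlorophenyl gained, with an 18-fold higher number from compound 3 to compound 4 (1.26 log units; beyond the scatter) as the largest step at this position so far. Against 3-hydroxyphenyl the step is a 2.1-fold higher number from compound 2 to compound 4 (0.33 log units; beyond the scatter) and against 2,5-dimethoxyphenyl it is a 1.9-fold higher number from compound 1 to compound 4 (0.28 log units; within the scatter) so the large gap belongs to compound 3 alone. Nothing measured here accounts for these differences. The compounds shown leave open whether a phenyl ring carrying a single chlorine atom, or an amine, would keep the low number of compound 3.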